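Swapping a ring hydroxy for iodo: what to expect

A few compounds are considered here, and "the series" means these few. Any claim that something is new, unique, unknown or untested is made for them only; others in the source may bear on it.

Compound 1 `C=C1C(=O)[C@]23C[C@@]1(Cl)CC[C@H]2[C@@]12C=CC(=O)[C@](C)(C(=O)O1)[C@H]2[C@@H]3C(=O)OC`: 4800 nM
Compound 2 `C=C1C(=O)[C@]23C[C@@]1(O)CC[C@H]2[C@@]12C=CC(=O)[C@](C)(C(=O)O1)[C@H]2[C@@H]3C(=O)OC`: 39600 nM
Compound 3 `C=C1C(=O)[C@]23C[C@@]1(O)CC[C@H]2[C@@]12C=CC(=O)[C@](C)(C(=O)O1)[C@H]2[C@@H]3C(=O)OCc1ccccc1`: 2500 nM

These three compounds were tested in a functional assay on MKN-28 cells (Homo sapiens) for cytotoxicity, read by MTT assay; a lower number here means a stronger inhibitor, a higher number a weaker inhibitor. Compound 2 stands highest of the three, and its gaps to compound 1 and to compound 3 are both beyond the scatter. The next compound to be measured, compound 4 `C=C1C(=O)[C@]23C[C@@]1(I)CC[C@H]2[C@@]12C=CC(=O)[C@](C)(C(=O)O1)[C@H]2[C@@H]3C(=O)OC`, has iodo in place of hydroxy on a saturated ring carbon.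

The closest evidence comes from compound 1, which carries chloro on that ring carbon and otherwise matches compound 2. The measured step, an 8.3-fold higher number from compound 1 to compound 2 (0.92 log units; beyond the scatter), is modest, and it runs from halogen to hydroxy. The change to compound 4 runs the opposite way, from hydroxy to a halogen, so a lower number is expected. The other measured step, a 16-fold lower number from compound 2 to compound 3 (1.20 log units; beyond the scatter), is large, but it concerns phenyl on a saturated chain carbon, a different place, and so says little here. For the measured compounds named here, no iodo compound has been measured yet, so carrying the chloro result over to iodo remains an assumption, and the range is kept wide.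

The expected step is an 8.8-fold lower number from compound 2 to compound 4 (0.94 log units; beyond the scatter), similar in size to the chloro step and beyond the scatter. For compound 4 the estimated value is 4500 nM, with an expected range from 1500 nM to 14000 nM.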

Compound 4, half-maximal inhibitory concentration: 6700 nM
The estimate for compound 4 lay 1.5-fold (0.17 log units) below the measured number, and the stated range covers the measured number.
By their numbers in this assay, from the lowest: compounds 3, 1 and 4 (each within the scatter of the next, the first and the last beyond it); then compound 2.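

In this assay, the step of a 5.9-fold lower number from compound 2 to compound 4 (0.77 log units; beyond the scatter) shows that the lower number seen with chloro on this saturated ring carbon is not confined to chloro, since iodo, a second halogen, also lies clearly below hydroxy. The step of a 1.4-fold higher number from compound 1 to compound 4 (0.14 log units; within the scatter) lies within the scatter, so this assay does not tell iodo from chloro at this place, and the two halogens can be treated as equivalent here, with compound 2 the one that stands apart among the three compounds that differ only on this carbon. Nothing available explains why hydroxy stands apart from the two halogens at this position.

The compounds shown leave open whether other groups on this ring carbon, such as fluoro, an amine or a methoxy group, would fall with the halogens or with hydroxy. They also leave open whether a halogen here and the phenyl on the saturated chain carbon bound to an oxygen next to a carbonyl group, which lowers the number in compound 3, would add up when both are present on the shared core.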